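The compounds below may be only part of what the source reports. "The series", "measured", "known", "first", "only" and "open" are said of these compounds alone.

Compound 1, with the structure `CCOC(CCn1c(Cc2nn(C)c(=O)c3ccccc23)nnc1SCCCCCCCC(=O)Nc1ccc(Cl)cc1Cl)OCC`, was tested in an assay on 32D cells for inhibition of interleukin-15 (Mus musculus), read by resazurin assay, with stated times of 30 min and 2.5 days, in the presence of a further agent that is not named here (a higher number here means a weaker inhibitor, a lower number a stronger inhibitor), where compound 1 gives 12100 nM. For the measured compounds named here, compound 1 stands as the only compound with a number here; the other value shown is a limit. Compound 2, with the structure `Cn1nc(Cc2nnc(SCC(=O)Nc3ccc(Cl)cc3Cl)n2CCC(=O)O)c2ccccc2c1=O`, reaches only a limit of the assay, > 30000 nM, and so carries no number, as noted in the limit of > 30000 nM in this assay, at which 1 of the 2 values shown sits. Compound 3, with the structure `Cn1nc(Cc2nnc(SCCCCCCCC(=O)Nc3ccc(Cl)cc3Cl)n2CCC(=O)O)c2ccccc2c1=O`, has not been measured. It differs from compound 1 in one place: carboxy in place of diethoxymethyl on a saturated chain carbon, two bonds along the chain from an aromatic nitrogen. Going by the values given here, no two measured compounds differ in only one place, so no measured step shows the size of such a change. Compound 2 carries a carboxy group on a shorter chain and sits at the limit described in the limit of > 30000 nM in this assay, at which 1 of the 2 values shown sits. The expected step is a 2.1-fold higher number from compound 1 to compound 3 (0.32 log units; beyond the scatter), toward weaker inhibition. Compound 3 is estimated at 25000 nM, within a range from 8000 nM to 60000 nM.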

Compound 3, half-maximal inhibitory concentration: 23500 nM
The estimate for compound 3 lay 1.1-fold (0.03 log units) above the measured number; the measured number falls inside the stated range.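

In this assay, the swap at this position, on a saturated chain carbon two bonds along the chain from an aromatic nitrogen, gives a 1.9-fold higher number from compound 1 to compound 3 (0.29 log units; within the scatter), so diethoxymethyl, with 7 heavy atoms, and carboxy, with 3 heavy atoms and 1 hydrogen-bond donor, cannot be told apart here. Compound 3 carries carboxy as compound 2 does and still gives a number, so carboxy at this position does not by itself bring a compound to the limit of the assay. Compound 2 is a limit and not a number: the limit of > 30000 nM in this assay, at which 1 of the 3 values shown sits.

On these data alone, the step between compound 2 and compound 3 cannot be read, so the part played by the shorter chain of compound 2 stays open. Also open, as far as these compounds go, is how an amine, or a longer chain ending in carboxy, would read at this position.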